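Halogen Swap on the Shared Core and HeLa Growth Inhibition

A few compounds are considered here, and "the series" means these few. Any claim that something is new, unique, unknown or untested is made for them only; others in the source may bear on it.

Compound 1 `O=C(/C=C\c1ccccc1)N1N=C(c2ccncc2)OC1c1c[nH]c2ccccc12`: > 30 ug/mL
Compound 2 `O=C(/C=C\c1ccccc1[N+](=O)[O-])N1N=C(c2ccncc2)OC1c1c[nH]c2ccccc12`: > 30 ug/mL
Compound 3 `O=C(/C=C\c1ccccc1F)N1N=C(c2ccncc2)OC1c1c[nH]c2ccccc12`: > 30 ug/mL

In an ADME assay on HeLa cells (Homo sapiens) for cytotoxicity, read by MTT assay, with a stated time of 72 h (a higher number here means a weaker inhibitor of growth, a lower number a stronger inhibitor of growth), compound 3 gives > 30 ug/mL, which is a limit of the assay and not a number. Compound 1 likewise gives only a limit, > 30 ug/mL, and so does compound 2 with > 30 ug/mL. Every measured value therefore sits at the limit of > 30 ug/mL in this assay, at which 3 of the 3 values shown sit, and the steps a step that the two limits leave unreadable from compound 1 to compound 2, a step that the two limits leave unreadable from compound 1 to compound 3 and a step that the two limits leave unreadable from compound 2 to compound 3 cannot be read in size. The shared core, then, has shown no growth inhibition within the tested range, whatever the substituent on the phenyl ring.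

Compound 4 `O=C(/C=C\c1ccc(Cl)cc1Cl)N1N=C(c2ccncc2)OC1c1c[nH]c2ccccc12` differs from compound 3 by 2,4-dichlorophenyl in place of 2-fluorophenyl on a double-bonded chain carbon bound to a double-bonded chain carbon. Going by the values given here, no measured step bears on this change in a readable way; the only guidance is that three different phenyl substituents all left the value at the limit. The expected step that the limit leaves unreadable from compound 3 to compound 4 is therefore none beyond the scatter. Compound 4 is estimated at 40 ug/mL, with a range from 15 ug/mL to 100 ug/mL, and another limit is the most likely outcome.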

Compound 4, concentration for 50% growth inhibition: 29.3 ug/mL
The estimate for compound 4 lay 1.4-fold (0.14 log units) above the measured number; the measured number falls inside the stated range.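

With 2,4-dichlorophenyl on the double-bonded chain carbon, the series gives its first number that is not a limit: in this assay compound 4 gives 29.3 ug/mL. Going by these compounds alone, its steps from the earlier compounds are only floors, an at least 1.0-fold lower number from compound 3 to compound 4 (0.01 log units; that floor lies within the scatter), an at least 1.0-fold lower number from compound 2 to compound 4 (0.01 log units; that floor lies within the scatter) and an at least 1.0-fold lower number from compound 1 to compound 4 (0.01 log units; that floor lies within the scatter), so this change cannot be said to have strengthened growth inhibition. The values of the other compounds are limits of the assay, and the steps among them cannot be read: the limit of > 30 ug/mL in this assay, at which 3 of the 4 values shown sit.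

Going by these compounds, it remains open whether both chlorines are needed for a number to appear, or whether one would do. On these data alone, it is also open whether a methoxy group or an amine on the same phenyl ring would give a number or another limit.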